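Removing a Methoxy Group: Expected Effect on Adenosine Binding

This account rests on a few compounds, and the source may have more. Where it says the series, first, only, none or still open, it means among the compounds named here.

Compound 1 `COc1ccc(-c2nc3c(NC4CCCC4)ncnc3n2C)cc1` was tested in an assay on CHO cells for displacement of a labelled ligand from adenosine receptor A1 (Homo sapiens), read by scintillation counting, with a stated time of 3 h (on this read-out lower numbers stand for stronger inhibition and higher numbers for weaker inhibition), and gave 75 nM. Of the two measured compounds, compound 1 shows the highest number; the other, compound 2 `CCCn1c(-c2ccccc2)nc2c(NC3CCCC3)ncnc21`, gives 10 nM in this assay, a gap beyond the usual scatter. Compound 3 `Cn1c(-c2ccccc2)nc2c(NC3CCCC3)ncnc21` has not yet been measured. It differs from compound 1 in one place: hydrogen in place of methoxy on an aromatic carbon. For the measured compounds named here, compound 2 also carries an unsubstituted phenyl ring and is the stronger binder of the pair, although it bears a different alkyl group on the core nitrogen, so no direct step to compound 3 is available. On that basis, the author expects the change from compound 1 to compound 3 to lower the number, by a step of a 2.5-fold lower number from compound 1 to compound 3 (0.40 log units; beyond the scatter), moving partway toward compound 2. For compound 3 the estimated value in this assay is 30 nM, with a range from 10 nM to 100 nM.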

Compound 3, inhibition constant: 2.8 nM
Compound 3: the middle estimate sits 11-fold (1.03 log units) above what was measured, and the stated range ends above it.
By their numbers in this assay, from the lowest: compound 3; then compound 2; then compound 1.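

In this assay, the change from 4-methoxyphenyl to phenyl gives a 27-fold lower number from compound 1 to compound 3 (1.43 log units; beyond the scatter), which shows that the number at this position, para to a large group, is highly sensitive to methoxy. Hydrogen in place of ethyl on a saturated chain carbon bound to an aromatic nitrogen gives a 3.6-fold lower number from compound 2 to compound 3 (0.55 log units; beyond the scatter), so with the phenyl ring unsubstituted, the alkyl group on the core nitrogen also matters, though the step is smaller than the one on the ring. No supporting measurement offers a reason for either step.

The compounds shown leave open how other groups on that aromatic carbon, such as fluorine, hydroxyl or an amine, would compare with hydrogen and methoxy. They also leave open whether hydrogen or an ethyl group on the core nitrogen would follow the same trend.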